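The source may report more compounds than this note shows. Statements on the series, on what has been measured and on what is new or still open speak of the compounds shown alone.

Compounds measured so far:
compound 1, `Nc1nc(=O)ccn1[C@@H]1O[C@H](COP(=O)(O)OP(=O)(O)O)[C@@H](O)[C@H]1O`, in an in vitro functional assay on 1321-N1 cells for agonist activity at P2Y purinoceptor 2 (Homo sapiens), read by scintillation proximity assay and inositol phosphate accumulation; on this read-out higher numbers stand for an effect only at larger amounts of compound and lower numbers for an effect already at smaller amounts: 604 nM
compound 2, `O=c1[nH]c(=S)ccn1[C@@H]1O[C@H](COP(=O)(O)O)[C@@H](O)[C@H]1O`, in this assay: > 100000 nM

For the measured compounds named here, compound 1 gives the only numerical value in this assay, at 604 nM. For compound 2 this assay reports a limit, > 100000 nM, and not a number; it sits at the limit of > 100000 nM in this assay, at which 1 of the 2 values shown sits. Going by the values given here, compound 1 and compound 2 differ in more than one place, so no single step connects them; their two values show only that one yields a number and the other a limit.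

Compound 3, `CSc1nc(=O)ccn1[C@@H]1O[C@H](COP(=O)(O)OP(=O)(O)O)[C@@H](O)[C@H]1O`, remains to be measured in this assay. It differs from compound 1 by methylsulfanyl in place of amino on an aromatic carbon. Among the compounds with values here, no measured step of this kind exists in the set, so the size of the step from compound 1 to compound 3 is open. A moderate loss in this assay is expected, and the estimated step is a 3.3-fold higher number from compound 1 to compound 3 (0.52 log units; beyond the scatter). Compound 3 is therefore estimated at 2000 nM in this assay, with a range from 400 nM to 10000 nM.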

Compound 3, half-maximal effective concentration: 523 nM
Compound 3: the middle estimate sits 3.8-fold (0.58 log units) above what was measured, within the range that was stated.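

At this position, between two ring nitrogen atoms, methylsulfanyl in place of amino on an aromatic carbon leaves compound 1 and compound 3 within the scatter of each other in this assay, with a 1.2-fold lower number from compound 1 to compound 3 (0.06 log units; within the scatter). In this one pair, then, the exchange removes the hydrogen-bond donor of amino and brings in a larger group without a step beyond the scatter, so an amino group is not required here for a value of this order. Nothing at hand bears on why the two values lie so close, and no cause can be given for this pair.

From the compounds shown here alone, whether the position also accepts a longer chain on the sulfur, such as ethylsulfanyl or benzylsulfanyl, or a different kind of group, such as methoxy or dimethylamino, remains open, and a single pair sets no trend for any of these. Also open, going by these compounds, is whether the same exchange gives a step of similar size in a compound carrying a triphosphate.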